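The compounds below may be only part of what the source reports. "The series", "measured", "known", "first", "only" and "open" are said of these compounds alone.

The measured compounds and their values:

Compound 1, `C=C(C)[C@@H]1CC=C(C)/C(=N/NC(=O)Nc2nnc(-c3ccc(F)cc3)o2)C1`, gives 300 mg/kg in a functional assay on the whole organism (strain Swiss albino) with Mus musculus as the target, with a stated time of 4 h; a higher number here means that more compound is needed for the effect, a lower number that less compound is needed.
Compound 2, `C=C(C)[C@@H]1CC=C(C)/C(=N/NC(=O)Nc2nnc(-c3ccc(C)cc3)o2)C1`, gives 300 mg/kg in this assay.
Compound 3, `CC(C)=CC/C=C(/C)C/C=N/NC(=O)Nc1nnc(-c2ccc(F)cc2)o1`, gives 300 mg/kg in this assay.

Compounds 1 and 2 share one core, while compound 3 is built on a different core; the difference between the two cores is not broken down here. Compound 1 and compound 2 differ by methyl in place of fluoro on an aromatic carbon, and the measured outcome of that change is no change at the digits printed from compound 1 to compound 2 (within the scatter). Compound 3 stands level with compound 1 and with compound 2, all three sitting within the scatter of one another, so no order among them can be read from these numbers.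

Compound 4, `CC(C)=CC/C=C(/C)C/C=N/NC(=O)Nc1nnc(-c2ccc(C)cc2)o1`, has not yet been tested in this assay. It differs from compound 3 by methyl in place of fluoro on an aromatic carbon, the same change, at the same place, that carries compound 1 to compound 2. The expectation for compound 4 therefore rests on that earlier step: it left the minimum effective dose where it was, and compound 3 starts from the same dose as compound 1. The expected step is no change at the digits printed from compound 3 to compound 4 (within the scatter), set beside the measured no change at the digits printed from compound 1 to compound 2 (within the scatter). Compound 4 is thus estimated to give 300 mg/kg in this assay, with a likely range from 150 mg/kg to 600 mg/kg.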

Compound 4, minimum effective dose: 300 mg/kg
Estimate against measurement, compound 4: no gap at the digits printed, and the stated range covers the measured number.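

In this assay, 4-methylphenyl in place of 4-fluorophenyl on the core of compound 3 gives no change at the digits printed from compound 3 to compound 4 (within the scatter), and this step agrees with the one measured for the same change on the core of compound 1: the same change on two cores in this assay, no change at the digits printed (within the scatter) from compound 1 to compound 2 and no change at the digits printed (within the scatter) from compound 3 to compound 4, 1.0-fold (0.00 log units) apart, within the scatter of two such steps

Within these four compounds, then, the change carries from one core to the other as a step of no measurable size, and neither core gives an exception. This does not show that the two cores respond alike to changes in general, since a pair of steps without size cannot show whether a step that really moved the minimum effective dose would carry over in the same way. It also rests on a single pair of compounds on each core, and it says nothing about how the two cores compare with each other or why the dose stays where it does.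

The compounds shown leave open whether any other group on the aromatic ring, such as a chloro, a methoxy or an amine, would shift the dose on either core. They also leave open whether a replacement of the whole 4-fluorophenyl ring, for instance by an unsubstituted pyridine, would behave the same way on both cores.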